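Adding a Second Methoxy Group to a Chalcone-Like Scaffold

The compounds below may be only part of what the source reports. "The series", "measured", "known", "first", "only" and "open" are said of these compounds alone.

Measured compounds:
- compound 1 `COc1ccc(-c2cc(/C=C/C(=O)c3ccc(N)cc3)[nH]n2)cc1`: 103%
- compound 2 `COc1ccc(C(=O)/C=C/c2cc(-c3cc(OC)c(OC)c(OC)c3)n[nH]2)cc1OC`: 89%

Compound 1 gives the highest of the two numbers in a functional assay on MDA-MB-468 cells (Homo sapiens) for cytotoxicity, read by sulforhodamine B assay, with a stated time of 48 h, tested at 0.01 uM (on this read-out lower numbers stand for a stronger effect and higher numbers for a weaker effect at the one concentration tested), meaning it shows almost no effect at the concentration tested. Compound 2 sits a number of points lower, a gap that lies beyond the scatter, so compound 2 shows the stronger effect of the two. The two compounds differ in several places at once, so no single change can be tied to that gap.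

Compound 3 `COc1ccc(-c2cc(/C=C/C(=O)c3ccc(N)cc3)[nH]n2)cc1OC` has not been measured. It differs from compound 1 in one place: methoxy in place of hydrogen on an aromatic carbon, a methoxy in place of hydrogen on an aromatic carbon. Going by the values given here, no measured pair isolates such a change, so there is no direct precedent. Because compound 1 gives 103%, essentially no effect, the change is expected to produce at most a small step, a number 6 percentage points lower from compound 1 to compound 3 (within the scatter), not clearly beyond the scatter. Compound 3 is expected to give about 97%, within 80% to 110%.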

Compound 3, a percentage reported as activity, at one concentration (the size of the read-out at that concentration, not a potency): 94%
Beside the measured number, compound 3's estimate is 3 percentage points above it, and the stated range covers the measured number.
By their numbers in this assay, from the lowest: compounds 2, 3 and 1 (each within the scatter of the next, the first and the last beyond it).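

Going by these compounds alone, this is the first comparison here in which only one place changes: a methoxy in place of hydrogen on an aromatic carbon, ortho to a methoxy group. In this assay this change gives a number 9 percentage points lower from compound 1 to compound 3 (within the scatter) and so makes no clear difference to the read-out at the one concentration tested, which means that this position accepts the added methoxy without a change that stands out from the usual variation between repeats. No measurement is available that would explain this result.

The compounds shown leave open whether a different group on this same aromatic carbon, such as a hydroxyl, a chlorine atom or a longer ethoxy chain, would shift the read-out clearly. They also leave open whether the added methoxy would matter at other concentrations.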